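A few compounds are considered here, and "the series" means these few. Any claim that something is new, unique, unknown or untested is made for them only; others in the source may bear on it.

Values in a functional assay on A549 cells (Homo sapiens) for cytotoxicity, read by MTT assay, with a stated time of 72 h; a lower number here means a stronger inhibitor, a higher number a weaker inhibitor:
- compound 1 `CCN(CC)Cc1ccc2nc(NC(=O)N/N=C/c3cn(Cc4ccc(Cl)cc4)c4ccccc34)sc2c1`: 2940 nM
- compound 2 `CN(C)Cc1ccc2nc(NC(=O)N/N=C/c3cn(Cc4ccc(Cl)cc4)c4ccccc34)sc2c1`: 840 nM
- compound 3 `CC1CCN(Cc2ccc3nc(NC(=O)N/N=C/c4cn(Cc5ccccc5)c5ccccc45)sc3c2)CC1`: 2340 nM

Compound 3 holds the second highest of the three numbers. It lies within the scatter of compound 1, while compound 2 sits lower by a gap beyond the scatter.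

Compound 4 `CC1CCN(Cc2ccc3nc(NC(=O)N/N=C/c4cn(Cc5ccc(Cl)cc5)c5ccccc45)sc3c2)CC1` differs from compound 3 by one change: chloro in place of hydrogen on an aromatic carbon, which turns benzyl into 4-chlorobenzyl. Going by the values given here, the only measured step, a 3.5-fold lower number from compound 1 to compound 2 (0.54 log units; beyond the scatter), is dimethylamino in place of diethylamino. It is a change elsewhere in the molecule, so it bears on this question only indirectly. Among the compounds with values here, no measured pair isolates chloro in place of hydrogen. Compound 1 and compound 2 both carry 4-chlorobenzyl. Compound 1 gives 2940 nM and compound 2 gives 840 nM, which fall on either side of compound 3, so no direction can be read from them. No step beyond the scatter is therefore expected, with at most a slight lean to a lower number.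

The estimated change is a 1.2-fold lower number from compound 3 to compound 4 (0.07 log units; within the scatter).

For compound 4 the expected value is 2000 nM, with an estimated range of 800 nM to 4500 nM.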

Compound 4, half-maximal inhibitory concentration: 2030 nM
The estimate for compound 4 lay 1.0-fold (0.01 log units) below the measured number; the measured number falls inside the stated range.
By their numbers in this assay, from the lowest: compound 2; then compounds 4, 3 and 1 (each within the scatter of the next).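

In this assay, going by these compounds alone, the step of a 1.2-fold lower number from compound 3 to compound 4 (0.06 log units; within the scatter) lies within the scatter and gives the first direct reading at this position: with 4-methylpiperidin-1-yl held constant, benzyl and 4-chlorobenzyl are not told apart. Among the compounds carrying 4-chlorobenzyl, the step of a 2.4-fold higher number from compound 2 to compound 4 (0.38 log units; beyond the scatter) lies beyond the scatter, while the step of a 1.4-fold lower number from compound 1 to compound 4 (0.16 log units; within the scatter) lies within it, so only the dimethylamino compound stands apart from the other two. No measured evidence on hand accounts for these readings.

Open, from the compounds shown here alone, is whether methoxy or fluoro on the same aromatic carbon would also stay within the scatter of hydrogen. Also open, going by these compounds, is whether chloro in place of hydrogen reads the same alongside dimethylamino, or how a morpholin-4-yl group on the saturated chain carbon would compare with dimethylamino.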